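A few compounds are considered here, and "the series" means these few. Any claim that something is new, unique, unknown or untested is made for them only; others in the source may bear on it.

Three compounds of the series have so far been run in a functional assay on the whole organism (Tail, strain ICR) with Mus musculus as the target, in the tail flick test, with a stated time of 30 min, at a dose of 25 umol/kg by the oral route; on this read-out higher numbers stand for a stronger effect at the one dose given and lower numbers for a weaker effect. Compound 1 `O=C(CN(c1nc(Cl)nc2[nH]cnc12)C1CC1)NCC(=O)OCc1ccccc1` gives 18.7%, compound 2 `O=C(CN(c1ncnc2c1ncn2C1CCCCO1)C1CC1)N[C@@H](CO)C(=O)OCc1ccccc1` gives 27.8%, and compound 3 `O=C(O)C[C@H](NC(=O)CN(c1nc(Cl)nc2[nH]cnc12)C1CC1)C(=O)O` gives 19.9%. Compound 2 holds the largest of the three numbers, yet compound 3 and compound 1 both lie within the scatter of it, so no order among the three is secure. Compound 4 `CC(C)[C@H](NC(=O)CN(c1ncnc2c1ncn2C1CCCCO1)C1CC1)C(=O)OCc1ccccc1` has not yet been measured. It differs from compound 2 in one place: isopropyl in place of hydroxymethyl on a saturated chain carbon bound to an amide-type nitrogen and a carbonyl carbon. Within the data shown here, no measured pair shows this change, so its effect in this assay is unknown; with the three measured numbers lying close together, no step beyond the scatter is expected in either direction. Compound 4 is therefore estimated at 25%, with a range from 10% to 40%. That estimate means an expected step of a number 2.8 percentage points lower from compound 2 to compound 4 (within the scatter).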

Compound 4, a percentage reported as activity, at one dose (the size of the read-out at that dose, not a potency): 21.8%
Compound 4: middle estimate off by 3.2 percentage points, on the high side; low and high end bracket the measured number.
By their numbers in this assay, from the lowest: compounds 1, 3, 4 and 2 (each within the scatter of the next).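

In this assay, among these compounds, the change to isopropyl in place of hydroxymethyl on a saturated chain carbon bound to an amide-type nitrogen and a carbonyl carbon gives the first one-place comparison (a number 6 percentage points lower from compound 2 to compound 4 (within the scatter)). At this position, hydroxymethyl with its hydrogen-bond donor and acceptor gives way to isopropyl, which has neither, without a step beyond the scatter. Nothing at hand bears on the reason for this result.

On these data alone, whether an amine, a carboxylic acid or a longer chain on this carbon would produce a step beyond the scatter remains open.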